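The source may report more compounds than this note shows. Statements on the series, on what has been measured and on what is new or still open speak of the compounds shown alone.

In a functional assay on HaCaT cells (Homo sapiens) for antiproliferative activity, read by sulforhodamine B assay, with a stated time of 3 days (a higher number here means a weaker inhibitor, a lower number a stronger inhibitor), compound 1 (`COC(=O)c1cc(CCc2ccc(OC)cc2OC)ccc1O`) gives 19000 nM while compound 2 (`COC(=O)c1cc(CCc2cc(Cl)ccc2OC)ccc1O`) gives 6900 nM and compound 3 (`CCc1ccc(OC)cc1CCc1ccc(O)c(C(=O)OC)c1`) gives 130 nM as the lowest number. Compound 2 thus holds the middle place, with its gaps to compound 1 and compound 3 both beyond the scatter and the second much the wider. Compound 4 (`CCc1ccc(OC)c(CCc2ccc(O)c(C(=O)OC)c2)c1`) has ethyl in place of chloro on an aromatic carbon, meta to a large group and para to a methoxy group (ethyl in place of chloro on an aromatic carbon). Among the measured compounds shown here, no measured pair shows this change on its own. For the measured compounds named here, compound 3 also carries an ethyl group and reads 130 nM here, but no one-place step links it to compound 4, so it offers only a weak lean towards a lower number. A modest fall in this assay is expected, though a result within the scatter cannot be excluded. The estimated move is a 2.8-fold lower number from compound 2 to compound 4 (0.44 log units; beyond the scatter) on this reasoning. For compound 4 the expected value is 2500 nM with an estimated range from 400 nM to 12000 nM for repeat measurements.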

Compound 4, half-maximal inhibitory concentration: 430 nM
The estimate for compound 4 lay 5.8-fold (0.76 log units) above the measured number, and the stated range covers the measured number.
By their numbers in this assay, from the lowest: compound 3; then compound 4; then compound 2; then compound 1.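

In this assay, among the compounds shown here, the exchange of chloro for ethyl on this aromatic carbon, meta to a large group and para to a methoxy group, is the first one-place change and gives a 16-fold lower number from compound 2 to compound 4 (1.21 log units; beyond the scatter) as a large step. The position therefore responds strongly to its substituent, although the change adds only one heavy atom and leaves the hydrogen-bond donor, hydrogen-bond acceptor and net charge counts unchanged. Nothing measured here bears on why this single step is so large.

As far as these compounds go, whether the gain is particular to ethyl remains open, as this one pair cannot separate it from what a methyl or a longer chain such as propyl would give at this position. From the compounds shown here alone, the response to an amine or a carboxylic acid on the same carbon also remains open.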